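Nitro in place of hydrogen on the distal aryl

This account rests on a few compounds, and the source may have more. Where it says the series, first, only, none or still open, it means among the compounds named here.

The series shares a core carrying two aryl groups and a linker that ends in a further aryl group. Compound 1 `Cc1ccc(-c2nnc(N3CCN(C(=O)CN4CCN(c5cccc(Cl)c5)CC4)CC3)nc2-c2ccc(C)cc2)cc1` and compound 2 `COc1ccc(-c2nnc(N3CCN(C(=O)CN4CCN(c5ccc(Cl)cc5)CC4)CC3)nc2-c2ccc(OC)cc2)cc1` carry methyl- and methoxy-bearing aryls on the core and a chlorophenyl at the linker end. In a functional assay on MCF7 cells (Homo sapiens) for cytotoxicity, read by MTT assay, with a stated time of 24 h (on this read-out higher numbers stand for weaker inhibition and lower numbers for stronger inhibition), compound 1 gives 797000 nM and compound 2 gives 607000 nM. Compound 3 `O=C(CN1CCN(c2ccccc2)CC1)N1CCN(c2nnc(-c3ccc(Cl)cc3)c(-c3ccc(Cl)cc3)n2)CC1` carries chlorophenyl groups on the core and an unsubstituted phenyl at the linker end. In this assay compound 3 reaches only the limit of > 850000 nM, so no number is available for it; (the limit of > 850000 nM in this assay, at which 1 of the 3 values shown sits). Compound 3 therefore stands on the numbers shown only as a limit, and its distance from the two numbered compounds cannot be read.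

Compound 4 `O=C(CN1CCN(c2ccc([N+](=O)[O-])cc2)CC1)N1CCN(c2nnc(-c3ccc(Cl)cc3)c(-c3ccc(Cl)cc3)n2)CC1` differs from compound 3 by nitro in place of hydrogen on an aromatic carbon, a nitro in place of hydrogen on an aromatic carbon. For the measured compounds named here, no pair of measured compounds tests this change, so the size of its step is open. A small step toward stronger inhibition or none beyond the scatter is expected in this assay, and the estimated step from compound 3 to compound 4 is an at least 1.2-fold lower number from compound 3 to compound 4 (0.08 log units; that floor lies within the scatter). Compound 4 is accordingly estimated at 700000 nM, within 300000 nM to 1500000 nM, with a fair chance that this assay again reports only a limit.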

Compound 4, half-maximal inhibitory concentration: > 789000 nM
Compound 4 gave a limit, no number; the forecaster's own chance of this, stated with the estimate: 45%; at least 1.1-fold (0.05 log units) between middle value and limit.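

Compound 3 and compound 4 each give only a limit, not a number, in this assay, and the step between them cannot be read. The compounds shown leave open whether nitro in place of hydrogen on an aromatic carbon shifts this read-out at all; no pair with two numbers tests that change.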